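A few compounds are considered here, and "the series" means these few. Any claim that something is new, unique, unknown or untested is made for them only; others in the source may bear on it.

Going by the values given here, in an ADME assay on L1210/0 cells (Mus musculus) for cytotoxicity, with a stated time of 48 h (a lower number here means a stronger inhibitor, a higher number a weaker inhibitor), two compounds sharing one core have numbers so far. Compound 1 `O=C1O/C(=C\Cn2cc(F)c(=O)[nH]c2=O)C(OCc2ccccc2)=C1OCc1ccccc1`, with a fluoro group on an aromatic carbon, gives 5100 nM, and compound 2 `O=C1O/C(=C\Cn2cc(I)c(=O)[nH]c2=O)C(OCc2ccccc2)=C1OCc1ccccc1`, with an iodo group on that same carbon, gives 7500 nM. These two values lie within the scatter of each other, so compound 2 cannot be ranked against compound 1.

Compound 3 `O=C1O/C(=C\Cn2ccc(=O)[nH]c2=O)C(OCc2ccccc2)=C1OCc1ccccc1` has no number yet. It differs from compound 2 at that carbon: hydrogen in place of iodo on an aromatic carbon, hydrogen in place of iodo. Among the compounds with values here, only one measured step bears on this change: a 1.5-fold higher number from compound 1 to compound 2 (0.17 log units; within the scatter). That step swapped one halogen for another and stayed small. Within the data shown here, no measured compound has hydrogen at this place, so the data give no direct view of losing the halogen altogether. Going by that small step and by compound 2 at 7500 nM, no change beyond the scatter is expected in this assay, though the uncertainty is wide. The expected step is a 1.1-fold lower number from compound 2 to compound 3 (0.03 log units; within the scatter). For compound 3, the estimate is 7000 nM, with an expected range from 3000 nM to 18000 nM.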

Compound 3, half-maximal inhibitory concentration: 12900 nM
For compound 3 the middle estimate is 1.8-fold (0.27 log units) below the measured one; the measured number falls inside the stated range.
By their numbers in this assay, from the lowest: compounds 1, 2 and 3 (each within the scatter of the next, the first and the last beyond it).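

In this assay, going by these compounds alone, hydrogen in place of fluoro gives a 2.5-fold higher number from compound 1 to compound 3 (0.40 log units; beyond the scatter) and so provides the first step at this carbon that lies beyond the scatter, which shows that the number can respond to what sits here, although the step is modest. Hydrogen in place of iodo gives a 1.7-fold higher number from compound 2 to compound 3 (0.24 log units; within the scatter) and stays within the scatter, so losing the halogen is not separated from keeping it when iodo is the halogen, and compound 2 cannot be ranked against either compound 1 or compound 3. The effect therefore rests on a single comparison between the fluoro compound and the compound with hydrogen, and no supporting measurement is available to explain it.

As far as these compounds go, it remains open how the number would respond to other groups on this carbon, such as chloro, bromo, methyl, an amine or a longer chain. All three compounds also share one core, so whether hydrogen in place of fluoro would give a similar step on a different core cannot be told from these values.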